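The source may hold more compounds than are shown below. What is called first, only, known or untested is meant among the compounds shown, and "the series" means these compounds.

Of the compounds shown here, three have been tested in an assay on CHO cells for displacement of a labelled ligand from adenosine receptor A1 (Homo sapiens), read by fluorescence, with a stated time of 1 h; a higher number here means a weaker inhibitor, a lower number a stronger inhibitor. Compound 1 `CSc1sc(NC(=O)C=C(C)C)nc1C` gives 29500 nM, far above the other two. Compound 2 `O=C(Nc1nc(C2CC2)cs1)c1cc2ccccc2s1` gives 3720 nM, and compound 3 `O=C(Nc1nc(C2CC2)cs1)c1ccoc1` gives 2950 nM; these two numbers sit within the usual scatter of each other, so they cannot be told apart, while compound 1 stands well beyond that scatter from both.

Compound 4 `CC(C)(C)C(=O)Nc1nc(C2CC2)cs1` shares the core of compound 3 and differs in one place: tert-butyl in place of furan-3-yl on a carbonyl carbon. For the measured compounds named here, no measured pair shows a change of this kind, so the expectation rests on the three numbers alone. Because compound 1 gives 29500 nM with a small acyl group on its amide, a weakening step is expected, and the estimate for the step from compound 3 to compound 4 is a 2.7-fold higher number from compound 3 to compound 4 (0.43 log units; beyond the scatter). Compound 4 is therefore expected to give about 8000 nM, within a range from 2500 nM to 30000 nM.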

Compound 4, inhibition constant: 12300 nM
For compound 4 the middle estimate is 1.5-fold (0.19 log units) below the measured one, and the stated range covers the measured number.
By their numbers in this assay, from the lowest: compounds 3 and 2 (each within the scatter of the next); then compound 4; then compound 1.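

In this assay, putting tert-butyl in place of furan-3-yl on the carbonyl carbon gives a 4.2-fold higher number from compound 3 to compound 4 (0.62 log units; beyond the scatter), so this position responds to the group it carries. The change removes the ring and its oxygen together, and a step beyond the scatter is now tied to this one place in the shared core. Nothing available explains the step.

Because both the ring and the oxygen leave at once, their separate shares stay unresolved. A phenyl ring or a straight propyl chain on that carbonyl carbon could begin to separate them.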